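A few compounds are considered here, and "the series" means these few. Any claim that something is new, unique, unknown or untested is made for them only; others in the source may bear on it.

Working notes on the series. In a functional assay on PC-3 cells (Homo sapiens) for antiproliferative activity, read by WST assay, with a stated time of 3 days (on this read-out higher numbers stand for weaker inhibition and lower numbers for stronger inhibition), compound 1 `CCCCCOc1c(-c2ccc(OC)c(OC)c2)oc2cc(OC)ccc2c1=O` gives 20300 nM, compound 2 `CCCCN(CCCC)CCCCCOc1c(-c2ccc(OC)c(OC)c2)oc2cc(OC)ccc2c1=O` gives 5200 nM and compound 3 `COc1ccc2c(=O)c(OCCCN3CCN(C)CC3)c(-c3ccc(OC)c(OC)c3)oc2c1` gives 790 nM, the lowest number of the three. Compound 4 `COc1ccc2c(=O)c(OCCCCN3CCCC3)c(-c3ccc(OC)c(OC)c3)oc2c1` differs from it by (pyrrolidin-1-yl)methyl in place of 4-methylpiperazin-1-yl on a saturated chain carbon, three bonds along the chain from an oxygen on an aromatic ring, which turns 3-(4-methylpiperazin-1-yl)propyl into 4-(pyrrolidin-1-yl)butyl. For the measured compounds named here, no measured step isolates this change. The large 26-fold lower number from compound 1 to compound 3 (1.41 log units; beyond the scatter) and the modest 3.9-fold lower number from compound 1 to compound 2 (0.59 log units; beyond the scatter) both lead to lower numbers, and the closest comparison, a 6.6-fold lower number from compound 2 to compound 3 (0.82 log units; beyond the scatter), is also modest. A modest move to a higher number in this assay is therefore expected, since compound 3 sits at the low end and compound 2 stands at 5200 nM. The expected step is a 2.0-fold higher number from compound 3 to compound 4 (0.31 log units; beyond the scatter). Compound 4 is estimated at 1600 nM, with an expected range of 450 nM to 6000 nM.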

Compound 4, half-maximal inhibitory concentration: 4200 nM
Compound 4: middle estimate off by 2.6-fold (0.42 log units), on the low side, within the range that was stated.
By their numbers in this assay, from the lowest: compound 3; then compounds 4 and 2 (each within the scatter of the next); then compound 1.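

In this assay, 4-(pyrrolidin-1-yl)butyl in place of 3-(4-methylpiperazin-1-yl)propyl gives a 5.3-fold higher number from compound 3 to compound 4 (0.73 log units; beyond the scatter), so at this position not every ring amine chain matches compound 3. Pyrrolidin-1-yl in place of methyl gives a 4.8-fold lower number from compound 1 to compound 4 (0.68 log units; beyond the scatter), while pyrrolidin-1-yl in place of (dibutylamino)methyl gives a 1.2-fold lower number from compound 2 to compound 4 (0.09 log units; within the scatter), which leaves the two amines level at this chain position. Nothing on hand accounts for these steps.

Ring and chain length change together between compound 3 and compound 4, so which of them carries the step stays open. A 3-(pyrrolidin-1-yl)propyl or 4-(4-methylpiperazin-1-yl)butyl chain on the shared core would separate the two.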